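The compounds below may be only part of what the source reports. "The series", "measured", "known", "first", "only" and "open" are said of these compounds alone.

Measured compounds in an assay on isolated protein for inhibition of malate dehydrogenase, mitochondrial (Sus scrofa), with stated times of 45 min and 30 min; a lower number here means a stronger inhibitor, a higher number a weaker inhibitor:
- compound 1 `O=S(=O)(Nc1ccc2oc(-c3ccccc3)nc2c1)c1ccccc1F` gives > 63000 nM, a limit of the assay
- compound 2 `O=S(=O)(Nc1ccc2oc(-c3ccccc3)nc2c1)c1ccc(Cl)cc1` gives > 63000 nM, a limit of the assay
- compound 3 `O=S(=O)(Nc1ccc2oc(-c3ccccc3)nc2c1)c1ccc(Cl)c(C(F)(F)F)c1` gives > 63000 nM, a limit of the assay

Compound 2 stands only at a limit in this assay, not at a measured number. The same holds for the two neighbours that differ from it in one place, so that a step that the two limits leave unreadable from compound 1 to compound 2 and a step that the two limits leave unreadable from compound 2 to compound 3 cannot be read as steps of any size. Within the data shown here, all three values sit at the same limit (the limit of > 63000 nM in this assay, at which 3 of the 3 values shown sit), and no measured step on this core gives a direction or a size to lean on.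

Compound 4 `O=S(=O)(Nc1ccc2oc(-c3ccccc3)nc2c1)c1cccs1` differs from compound 2 by thiophen-2-yl in place of 4-chlorophenyl on a sulfonyl sulfur. Both steps that touch compound 2 swap a group on the sulfonyl sulfur or on its ring, and so bear on this change. Each of them is unreadable. No step beyond the scatter is therefore expected in this assay; the most likely outcome for compound 4 is again a limit. As an estimate, compound 4 is expected at 100000 nM, in the range 30000 nM to 400000 nM, meaning an expected step that the limit leaves unreadable from compound 2 to compound 4.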

Compound 4, half-maximal inhibitory concentration: > 63000 nM
Compound 4: only a limit was reported (the forecaster's own chance of this, stated with the estimate: 85%); the middle value lies beyond the limit too.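

Compound 4 also stands only at a limit, so the steps from compound 1 and from compound 2 to compound 4 cannot be read as steps of any size: the limit of > 63000 nM in this assay, at which 4 of the 4 values shown sit.

The compounds shown leave open how strongly any of them acts in this assay, and whether changing the group on the sulfonyl sulfur alters that at all.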